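The source may report more compounds than this note shows. Statements on the series, on what has been measured and on what is new or still open speak of the compounds shown alone.

Measured so far in a functional assay on HL-60 cells (Homo sapiens) for inhibition, read by CCK-8 assay, with a stated time of 48 h, tested at 20 uM; a higher number here means more inhibition of growth at the concentration tested, a lower number less inhibition of growth:
compound 1 `COc1ccc(S(=O)(=O)Oc2ccccc2/C=C(\C#N)C(=O)Nc2nnc(-c3cccs3)s2)cc1` gives 67%
compound 2 `COc1ccc(S(=O)(=O)Oc2ccccc2/C=C(\C#N)C(=O)Nc2nnc(Cc3cccc(F)c3)s2)cc1` gives 100%
compound 3 `Cc1ccc(S(=O)(=O)Oc2ccccc2/C=C(\C#N)C(=O)Nc2nnc(Cc3ccc(Cl)cc3)s2)cc1` gives 15%

Compound 3 stands lowest of the three, beyond the scatter from both others. Compound 4 `COc1ccc(S(=O)(=O)Oc2ccccc2/C=C(\C#N)C(=O)Nc2nnc(Cc3ccc(Cl)cc3)s2)cc1` differs from it by methoxy in place of methyl on an aromatic carbon with methoxy in place of methyl on an aromatic carbon, para to a large group. Among the measured compounds shown here, no measured step covers this place. For the measured compounds named here, the one step available, a number 33 percentage points higher from compound 1 to compound 2 (beyond the scatter), is large but concerns 3-fluorobenzyl in place of thiophen-2-yl, so it shows only that values can move widely. Compound 1 at 67% and compound 2 at 100% both carry methoxy, though they differ from compound 3 elsewhere too, so a large upward move is expected, with much uncertainty. The expected step is a number 35 percentage points higher from compound 3 to compound 4 (beyond the scatter) as an estimate. The estimate for compound 4 is 50% with an expected range of 15% to 90%.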

Compound 4, percent growth inhibition at one concentration: 99%
Beside the measured number, compound 4's estimate is 49 percentage points below it; the whole stated range lies below it.
By their numbers in this assay, from the lowest: compound 3; then compound 1; then compounds 4 and 2 (each within the scatter of the next).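

In this assay, methoxy in place of methyl on the aromatic carbon para to a large group gives a number 84 percentage points higher from compound 3 to compound 4 (beyond the scatter), the first step read at this position. With methoxy kept, 4-chlorophenyl in place of 3-fluorophenyl gives a number 1 percentage points lower from compound 2 to compound 4 (within the scatter), whereas 4-chlorobenzyl in place of thiophen-2-yl gives a number 32 percentage points higher from compound 1 to compound 4 (beyond the scatter). Nothing available bears on the cause of these steps.

The methyl-to-methoxy step is shown only with 4-chlorobenzyl, so its size with 3-fluorobenzyl or thiophen-2-yl remains open. Also open, going by these compounds, is how a hydroxy group, an amine or an ethoxy group would read at this position.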